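Swapping the Amide Aryl Group: Cytotoxicity Outlook for Compound 4

The source may report more compounds than this note shows. Statements on the series, on what has been measured and on what is new or still open speak of the compounds shown alone.

Compound 2 `COc1ccc(-n2c(SC(C)C(=O)Nc3nc(C)cc(Cl)n3)nc3ccccc32)cc1` is one of three members of this set with a shared core. In an ADME assay on Vero cells (Chlorocebus sabaeus) for cytotoxicity, read by MTT assay, with a stated time of 24 h (a lower number here means that less compound is tolerated, a higher number that more compound is tolerated), compound 2 has no number, its entry reading "not determined" (no result reported). Compound 3 `COc1ccc(-n2c(S(=O)(=O)C(C)C(=O)Nc3ccc(C)cc3Cl)nc3ccccc32)cc1` likewise has no number in this assay, its entry being "not determined" (no result reported). For the measured compounds named here, compound 1 `COc1ccc(-n2c([S+]([O-])C(C)C(=O)Nc3ccc(C)cc3Cl)nc3ccccc32)cc1` is the only member with a result in this assay, and that result is a limit of the assay rather than a number, > 75000 nM. Going by the values given here, the one piece of evidence is therefore (the limit of > 75000 nM in this assay, at which 1 of the 3 values shown sits). Compound 4 `COc1ccc(-n2c(SC(C)C(=O)Nc3cc(C)nn3C)nc3ccccc32)cc1` is not yet measured; it differs from compound 2 by 1,3-dimethyl-1H-pyrazol-5-yl in place of 4-chloro-6-methylpyrimidin-2-yl on an amide-type nitrogen. No step between measured compounds is shown, so no shift beyond the scatter is expected in this assay for this change. Compound 4 is estimated at 100000 nM, with a range from 40000 nM to 300000 nM.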

Compound 4, half-maximal cytotoxic concentration: 75000 nM
Compound 4: middle estimate off by 1.3-fold (0.12 log units), on the high side, within the range that was stated.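

For the compounds shown here, no step from compound 2 to compound 4 can be read in this assay, as compound 2 has no number there. The compounds shown leave open how 1,3-dimethyl-1H-pyrazol-5-yl compares with 4-chloro-6-methylpyrimidin-2-yl on the amide-type nitrogen.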